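Amine Swap on a Longer Chain: Lipophilicity Expected Unchanged

The source may hold more compounds than are shown below. What is called first, only, known or untested is meant among the compounds shown, and "the series" means these compounds.

Measured compounds:
compound 1 `COc1cc(/C=C/C(=O)Nc2ccccc2)ccc1OCCCCN1CCCCC1` 1.61
compound 2 `COc1cc(/C=C/C(=O)Nc2ccccc2)ccc1OCCCCN1CCCC1` 1.6
compound 3 `COc1cc(/C=C/C(=O)Nc2ccccc2)ccc1OCCCCCN(C)C` 1.61

In a physicochemical assay for lipophilicity, using the shake flask method, measured as octanol-water partition, at pH 7.4 (a lower number here means a more polar compound, a higher number a more lipophilic compound), compound 3 stands level with compound 1 at the digits shown, and its nearest neighbour is compound 1 with no change at the digits printed from compound 1 to compound 3 (within the scatter); its furthest is compound 2, yet even there the gap is a number 0.01 log units higher from compound 2 to compound 3 (within the scatter). All three measured compounds therefore sit within the scatter of one another.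

Compound 4 `COc1cc(/C=C/C(=O)Nc2ccccc2)ccc1OCCCCCN1CCCC1` has not yet been measured. It differs from compound 3 by pyrrolidin-1-yl in place of dimethylamino on a saturated chain carbon, five bonds along the chain from an oxygen on an aromatic ring, the same exchange of terminal amine that the measured set already shows at the shorter chain, where a number 0.01 log units higher from compound 2 to compound 3 (within the scatter) runs in the opposite direction and a number 0.01 log units lower from compound 1 to compound 2 (within the scatter) replaces a six-membered by a five-membered ring. Neither of these rose above the scatter, and nothing in the set points to the extra chain carbon in compound 4 behaving differently. He therefore expects no step beyond the scatter in this assay for compound 4, with a number 0.01 log units lower from compound 3 to compound 4 (within the scatter) as the estimated step. His estimate for compound 4 in this assay is 1.6, within the range 1.3 to 1.9.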

Compound 4, partition coefficient: 1.64
For compound 4 the middle estimate is 0.04 log units below the measured one, and the stated range covers the measured number.
By their numbers in this assay, from the lowest: compounds 2, 1, 3 and 4 (each within the scatter of the next).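

In this assay the exchange of dimethylamino for pyrrolidin-1-yl, five bonds along the chain from an oxygen on an aromatic ring, gives a number 0.03 log units higher from compound 3 to compound 4 (within the scatter) at this position, so going from no ring to one five-membered non-aromatic ring, with 5 heavy atoms in place of 3, does not rise above the scatter here. The set now also holds a pair that keeps the pyrrolidin-1-yl amine and alters only the chain, and a number 0.04 log units higher from compound 2 to compound 4 (within the scatter) shows that (pyrrolidin-1-yl)methyl in place of pyrrolidin-1-yl, four bonds along the chain from that oxygen, likewise stays unresolved. The step that changes ring size and chain together, (pyrrolidin-1-yl)methyl in place of piperidin-1-yl, gives a number 0.03 log units higher from compound 1 to compound 4 (within the scatter) and adds no exception, so all four compounds remain within the scatter of one another.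

From the compounds shown here alone, whether this holds for an amine of another kind, such as a morpholine, a piperazine or a primary amine, or for a still longer chain, stays open, as does any change to the shared core. Nothing available here speaks to why these amines read alike.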